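Fluoro in place of hydrogen: what compound 4 may give

This account rests on a few compounds, and the source may have more. Where it says the series, first, only, none or still open, it means among the compounds named here.

Three compounds have been measured in an assay on cells for antagonist activity at transient receptor potential cation channel subfamily V member 1 (Homo sapiens), read by FLIPR and calcium flux, with a stated time of 15 min; a higher number here means a weaker inhibitor, a lower number a stronger inhibitor:
compound 1, `CC1CCN(c2nc(C(F)(F)F)ccc2CNC(=O)C(C)c2ccc(NS(C)(=O)=O)c(Br)c2)CC1`, 3.2 nM;
compound 2, `CC1CCN(c2nc(C(F)(F)F)ccc2CNC(=O)C(C)c2cc(F)c(NS(C)(=O)=O)c(Br)c2)CC1`, 0.7 nM;
compound 3, `COc1cc(C(C)C(=O)NCc2ccc(C(F)(F)F)nc2N2CCC(C)CC2)ccc1NS(C)(=O)=O`, 0.8 nM.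

Compound 3 stands second of the three numbers, close to compound 2 within the scatter, and well apart from compound 1, the step being a 4.0-fold lower number from compound 1 to compound 3 (0.60 log units; beyond the scatter). Compound 4, `COc1cc(C(C)C(=O)NCc2ccc(C(F)(F)F)nc2N2CCC(C)CC2)cc(F)c1NS(C)(=O)=O`, differs from compound 3 by fluoro in place of hydrogen on an aromatic carbon. Among the compounds with values here, one measured step bears directly on it: the same change, made elsewhere in this set, gave a 4.6-fold lower number from compound 1 to compound 2 (0.66 log units; beyond the scatter), a modest shift toward a stronger inhibitor. A step of similar size and direction is therefore expected in this assay, although a single precedent allows only moderate confidence. The expected step is a 2.7-fold lower number from compound 3 to compound 4 (0.43 log units; beyond the scatter). Compound 4 is estimated at 0.3 nM, with a range from 0.1 nM to 1 nM.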

Compound 4, inhibition constant: 0.3 nM
The estimate for compound 4 equals the measured number at the digits printed, within the range that was stated.
By their numbers in this assay, from the lowest: compound 4; then compounds 2 and 3 (each within the scatter of the next); then compound 1.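

With a methoxy group on the ring, fluoro ortho to a methanesulfonamido group still gives a 2.7-fold lower number from compound 3 to compound 4 (0.43 log units; beyond the scatter), so the gain in this assay is not tied to the bromo group. Methoxy in place of bromo likewise gives a 2.3-fold lower number from compound 2 to compound 4 (0.37 log units; beyond the scatter) with the fluoro present, in line with its step without fluoro: the same change on two cores in this assay, a 4.0-fold lower number (0.60 log units; beyond the scatter) from compound 1 to compound 3 and a 2.3-fold lower number (0.37 log units; beyond the scatter) from compound 2 to compound 4, 1.7-fold (0.23 log units) apart, within the scatter of two such steps Each change thus keeps its size whichever form of the other group is present, across these four compounds: the same change on two cores in this assay, a 4.6-fold lower number (0.66 log units; beyond the scatter) from compound 1 to compound 2 and a 2.7-fold lower number (0.43 log units; beyond the scatter) from compound 3 to compound 4, 1.7-fold (0.23 log units) apart, within the scatter of two such steps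

From the compounds shown here alone, whether chloro, a methyl group or a nitrile at this position would match fluoro remains open, as does whether an ethoxy group would match methoxy.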